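Substitution on the amide-bound phenyl of compound 1

The compounds below may be only part of what the source reports. "The series", "measured", "known", "first", "only" and "open" are said of these compounds alone.

Measured so far:
compound 1 `O=C(NC1CCN(Cc2ccc3ccccc3c2)CC1)c1ccccc1` 347 nM
compound 2 `COc1cc(OC)cc(C(=O)NC2CCN(Cc3ccc4ccccc4c3)CC2)c1` 27 nM
compound 3 `CCOc1cc(OCC)cc(C(=O)NC2CCN(Cc3ccc4ccccc4c3)CC2)c1` 56 nM

In an assay on isolated protein for binding affinity to melanin-concentrating hormone receptor 1 (Homo sapiens) (a higher number here means a weaker inhibitor, a lower number a stronger inhibitor), compound 1 stands highest of the three numbers; compound 3 gives 56 nM and compound 2 gives 27 nM, both well under it. Compound 4 `O=C(NC1CCN(Cc2ccc3ccccc3c2)CC1)c1ccc(F)c(F)c1` differs from compound 1 by 3,4-difluorophenyl in place of phenyl on a carbonyl carbon. Among the measured compounds shown here, the one measured step at the same carbonyl carbon is a 13-fold lower number from compound 1 to compound 2 (1.11 log units; beyond the scatter), a large drop, and compound 3 sits well under compound 1 too. Both bear on compound 4 only loosely, since the groups entering differ from those cases. Compared with compound 2, a smaller downward step is expected for compound 4: a 2.3-fold lower number from compound 1 to compound 4 (0.36 log units; beyond the scatter). Compound 4 is estimated at 150 nM, within 60 nM to 400 nM.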

Compound 4, inhibition constant: 18 nM
For compound 4 the middle estimate is 8.3-fold (0.92 log units) above the measured one; measured number outside the range, below it.
By their numbers in this assay, from the lowest: compounds 4 and 2 (each within the scatter of the next); then compound 3; then compound 1.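

At this carbonyl carbon, 3,4-difluorophenyl in place of phenyl gives a 19-fold lower number from compound 1 to compound 4 (1.29 log units; beyond the scatter) in this assay, so a large drop at this place does not depend on methoxy groups. Going from 3,5-dimethoxyphenyl to 3,4-difluorophenyl gives a 1.5-fold lower number from compound 2 to compound 4 (0.18 log units; within the scatter), so this assay does not separate these two substituted phenyl groups. Nothing at hand accounts for either step. Open, from the compounds shown here alone, is whether both fluorines are required for the drop, and how a phenyl carrying a single fluorine, a chlorine, a nitrile or an amine would compare.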